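Piperidinylmethyl in Place of a Diethylcarbamoyl Group

A few compounds are considered here, and "the series" means these few. Any claim that something is new, unique, unknown or untested is made for them only; others in the source may bear on it.

Among the measured compounds shown here, in a functional assay on the whole organism with Rattus norvegicus as the target (on this read-out higher numbers stand for an effect only at larger amounts of compound and lower numbers for an effect already at smaller amounts), compound 3 `CCN(CC)C(=O)Cn1c(=N)sc2cc(OC(F)(F)F)ccc21` gives 9 mg/kg, the only number among the three values shown. Compound 1 `CC(C)c1ccc2nc(N)sc2c1` reaches only a limit of the assay, > 10 mg/kg. Compound 2 `Nc1nc2cc(OC(F)(F)F)ccc2s1` likewise stops at a limit, > 10 mg/kg. Where the results fall is summed up by the limit of > 10 mg/kg in this assay, at which 2 of the 3 values shown sit. Compound 4 `N=c1sc2cc(OC(F)(F)F)ccc2n1CCN1CCCCC1` has not yet been tested. It differs from compound 3 in one place: (piperidin-1-yl)methyl in place of diethylcarbamoyl on a saturated chain carbon bound to an aromatic nitrogen. For the measured compounds named here, no pair of measured compounds differs in a single place, so no measured step guides the outlook. The expected step of a 1.1-fold lower number from compound 3 to compound 4 (0.05 log units; within the scatter) in this assay is none beyond the usual scatter, with the outcome open in either direction. Compound 4 is estimated at 8 mg/kg, in a range from 3 mg/kg to 20 mg/kg.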

Compound 4, dose for half-maximal effect: 2 mg/kg
Compound 4: the middle estimate sits 4.0-fold (0.60 log units) above what was measured; the measured number lies below the stated range.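

In this assay, (piperidin-1-yl)methyl in place of diethylcarbamoyl on a saturated chain carbon bound to an aromatic nitrogen gives a 4.5-fold lower number from compound 3 to compound 4 (0.65 log units; beyond the scatter), so the group at this position clearly matters. The change removes a carbonyl and brings in a ring, and the effect now appears at smaller amounts. This is the first step that can be read here, because the other two compounds stop at a limit: the limit of > 10 mg/kg in this assay, at which 2 of the 4 values shown sit.

The compounds shown do not separate the loss of the carbonyl from the gain of the ring. A morpholine or pyrrolidine ring in place of the piperidine, or a longer chain, would speak to that.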